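The source may hold more compounds than are shown below. What is called first, only, known or untested is meant among the compounds shown, and "the series" means these compounds.

Among the measured compounds shown here, compound 1, `COC(=O)C1C(=O)C=C(NCc2ccccc2)CC1C`, is one of two compounds measured in an in vivo functional assay on the whole organism (Hindlimb, Mus musculus); on this read-out higher numbers stand for an effect only at larger amounts of compound and lower numbers for an effect already at smaller amounts. In this assay compound 1 gives 42 mg/kg, the lowest of the two numbers available. The other compound, compound 2, `CC1(C)CC(O)=C/C(=N\Cc2ccccc2)C1`, gives 53 mg/kg in this assay; the gap between the two lies within the usual scatter, so nothing can be read from it about order or change. Compound 3, `COC(=O)C1C(=O)C=C(NCc2ccc(F)cc2)CC1C`, has not yet been measured. It differs from compound 1 in one place: fluoro in place of hydrogen on an aromatic carbon. For the measured compounds named here, no step between measured compounds shows what this change does in this assay, so a step beyond the scatter is not expected in either direction. The expected step of a 1.2-fold lower number from compound 1 to compound 3 (0.07 log units; within the scatter) is small. Compound 3 is accordingly estimated at 36 mg/kg in this assay, with a range from 15 mg/kg to 85 mg/kg.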

Compound 3, dose for half-maximal effect: 159 mg/kg
For compound 3 the middle estimate is 4.4-fold (0.65 log units) below the measured one; measured number outside the range, above it.
By their numbers in this assay, from the lowest: compounds 1 and 2 (each within the scatter of the next); then compound 3.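

In this assay, among the compounds shown here, the change from phenyl to 4-fluorophenyl gives a 3.8-fold higher number from compound 1 to compound 3 (0.58 log units; beyond the scatter), the first step that lies beyond the scatter. This shows that the aromatic carbon para to a large group is not indifferent to substitution on the core of compound 1: with fluoro in place of hydrogen, an effect appears only at larger amounts of compound, although this rests on a single pair. No available evidence bears on why this step arises.

The compounds shown leave open whether this loss is specific to fluoro or would also follow from chloro, methyl or methoxy at the same carbon, and whether fluoro elsewhere on the ring would act alike. They also leave open whether the same change would give a similar step on the core of compound 2.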